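The source may hold more compounds than are shown below. What is called first, only, known or untested is meant among the compounds shown, and "the series" means these compounds.

For the measured compounds named here, in a functional assay on CWR22R cells (Homo sapiens) for inhibition, read by sulforhodamine B assay, with a stated time of 72 h (on this read-out higher numbers stand for weaker inhibition and lower numbers for stronger inhibition), compound 1 `COc1ccc(Cn2nnc(O)c2C(=O)Nc2cccc(-c3ccc(O)cc3)c2)cc1` gives 67500 nM and compound 2 `COc1ccc(Cn2nnc(O)c2C(=O)Nc2cccc(-c3cccc(O)c3)c2)cc1` gives 75700 nM, so compound 2 stands level with the only other measured compound. Compound 3 `COc1ccc(Cn2nnc(O)c2C(=O)Nc2cccc(-c3ccc(OC)cc3)c2)cc1` carries 4-methoxyphenyl in place of 3-hydroxyphenyl on an aromatic carbon. Going by the values given here, the single measured step, a 1.1-fold higher number from compound 1 to compound 2 (0.05 log units; within the scatter), exchanged 4-hydroxyphenyl for 3-hydroxyphenyl and stayed within the scatter. Among the compounds with values here, no measured step tests a methoxyphenyl group, so the evidence is thin, and no shift beyond the scatter is expected in this assay. The expected step is a 1.1-fold lower number from compound 2 to compound 3 (0.03 log units; within the scatter). The estimated value for compound 3 is 70000 nM, with an expected range of 30000 nM to 140000 nM.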

Compound 3, half-maximal inhibitory concentration in the CWR22R assay: 50100 nM
Compound 3: middle estimate off by 1.4-fold (0.15 log units), on the high side, within the range that was stated.
By their numbers in the CWR22R assay, from the lowest: compounds 3, 1 and 2 (each within the scatter of the next).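

In the CWR22R assay, methyl in place of hydrogen on the oxygen gives a 1.3-fold lower number from compound 1 to compound 3 (0.13 log units; within the scatter), and 4-methoxyphenyl in place of 3-hydroxyphenyl gives a 1.5-fold lower number from compound 2 to compound 3 (0.18 log units; within the scatter), so neither change at this position moves this read-out beyond the scatter. The exchange of 3-hydroxyphenyl for 4-methoxyphenyl does separate the two compounds in a physicochemical assay for solubility, read by HPLC, in phosphate buffer, with a stated time of 24 h, at pH 7.4; on this read-out lower numbers stand for lower solubility and higher numbers for higher solubility: the measured solubility of compound 2, 40300 nM, and of compound 3, < 1000 nM, an at least 40-fold lower number (1.60 log units; beyond the scatter) In the physicochemical assay compound 2 gives 40300 nM. In the physicochemical assay compound 3 gives < 1000 nM, which is a limit of the assay, not a number: the limit of < 1000 nM in the physicochemical assay, at which 1 of the 2 values shown sits.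

Going by these compounds, it remains open whether an amine or a carboxylic acid on this phenyl ring would shift the number in the CWR22R assay beyond the scatter. On these data alone, it also remains open how such a group would read in the physicochemical assay.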